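Amide nitrogen variation on a stilbene-acrylamide scaffold

The source may report more compounds than this note shows. Statements on the series, on what has been measured and on what is new or still open speak of the compounds shown alone.

Measured compounds:
compound 1, `COc1ccc(/C=C/c2cc(OC)cc(OC)c2/C=C/C(=O)Nc2cc(OC)c(OC)c(OC)c2)cc1`, 7010 nM
compound 2, `COc1ccc(/C=C/c2cc(OC)cc(OC)c2/C=C/C(=O)N2CCN(C)CC2)cc1`, 2290 nM
compound 3, `C#CCNC(=O)/C=C/c1c(/C=C/c2ccc(OC)cc2)cc(OC)cc1OC`, 4560 nM

In a functional assay on MCF7 cells (Homo sapiens) for inhibition, read by MTT assay, with a stated time of 48 h (on this read-out lower numbers stand for stronger inhibition and higher numbers for weaker inhibition), compound 3 stands second highest of the three numbers. The nearest step is a 1.5-fold lower number from compound 1 to compound 3 (0.19 log units; within the scatter); the furthest is a 2.0-fold higher number from compound 2 to compound 3 (0.30 log units; within the scatter). Both steps change only the substituent on the amide nitrogen, and both stay within the scatter.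

Compound 4, `COc1ccc(/C=C/c2cc(OC)cc(OC)c2/C=C/C(=O)N(CC(C)C)CC(C)C)cc1`, has not yet been measured. It differs from compound 3 by diisobutylamino in place of propargylamino on a carbonyl carbon. The two steps that bear on this change are the same two: the step from compound 1 to compound 3 and the step from compound 2 to compound 3, each exchanging the amide nitrogen substituent without moving the number beyond the scatter. On that basis the expected step from compound 3 to compound 4 in this assay is a 1.0-fold lower number from compound 3 to compound 4 (0.01 log units; within the scatter), which is to say no change beyond the scatter in either direction. Compound 4 is therefore estimated at 4500 nM in this assay, with a range from 1500 nM to 14000 nM.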

Compound 4, half-maximal inhibitory concentration: 2390 nM
Estimate against measurement, compound 4: 1.9-fold (0.27 log units) above; measured number inside the range.
By their numbers in this assay, from the lowest: compounds 2, 4, 3 and 1 (each within the scatter of the next, the first and the last beyond it).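

In this assay the exchange of propargylamino for diisobutylamino on the carbonyl carbon gives a 1.9-fold lower number from compound 3 to compound 4 (0.28 log units; within the scatter) and so stays within the scatter, although the entering group has 9 heavy atoms against 4 and lacks the triple bond and the amide hydrogen. The earlier tertiary amide, compound 2, carries its nitrogen in the ring of 4-methylpiperazin-1-yl, whereas diisobutylamino has no ring, and the exchange between these two groups gives a 1.0-fold higher number from compound 2 to compound 4 (0.02 log units; within the scatter), so this read-out does not distinguish them at this position. No accompanying measurement bears on these results.

The compounds shown leave open whether a substituent on the amide nitrogen carrying a carboxylic acid, a primary amine or a much longer unbranched chain, such as dodecyl, would also stay within the scatter of these values. They also leave open whether the same tolerance holds when the shared core is changed, since all four compounds keep that core and vary only the group on the carbonyl carbon.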